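The compounds below may be only part of what the source reports. "The series", "measured", "known", "first", "only" and "open" are said of these compounds alone.

Measured so far in a functional assay on the whole organism with Mus musculus as the target; a higher number here means that more compound is needed for the effect, a lower number that less compound is needed:
compound 1 `CC(C)NC(=O)c1cccnc1Oc1ccc(F)cc1` gives 0.001 mg/kg
compound 2 `O=C(Nc1ccccc1)c1cccnc1Oc1ccc(F)cc1` gives 0.001 mg/kg
compound 3 `N#Cc1cccc(Oc2ncccc2C(=O)NCc2ccccc2)c1` gives 0.1 mg/kg

Among the measured compounds shown here, compound 3 holds the highest minimum effective dose of the three; compound 1 and compound 2 both sit below it, beyond the scatter, and the single one-place step, no change at the digits printed from compound 1 to compound 2 (within the scatter), shows the amide-side exchange leaving the read-out untouched within the scatter.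

The next compound, compound 4 `COc1ccc(Oc2ncccc2C(=O)NCc2ccccc2)cc1`, keeps the core and the amide side of compound 3 and changes only the aryl ether: 4-methoxyphenyl in place of 3-cyanophenyl on an oxygen on an aromatic ring. For the measured compounds named here, no measured step touches this position. Going by the values given here, compound 1 and compound 2 differ from compound 3 in two places at once, so their gap to compound 3 cannot be assigned to either place, and the one step that is known, no change at the digits printed from compound 1 to compound 2 (within the scatter), concerns the amide nitrogen and gives no guide for the aryl ether. The expectation for this assay therefore rests on compound 3 alone, with wide uncertainty, leaning toward a smaller dose because compound 1 shows 0.001 mg/kg and compound 2 shows 0.001 mg/kg, so such doses are reachable in this series.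

Compound 4 is estimated at 0.03 mg/kg (range 0.003 mg/kg to 0.3 mg/kg), which corresponds to an expected step of a 3.3-fold lower number from compound 3 to compound 4 (0.52 log units; beyond the scatter).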

Compound 4, minimum effective dose: 0.01 mg/kg
For compound 4 the middle estimate is 3.0-fold (0.48 log units) above the measured one; the measured number falls inside the stated range.
By their numbers in this assay, from the lowest: compounds 1 and 2 (each within the scatter of the next); then compound 4; then compound 3.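

In this assay, among the compounds shown here, the aryl ether is the first place where a one-place exchange moves the read-out beyond the scatter: 4-methoxyphenyl in place of 3-cyanophenyl on an oxygen on an aromatic ring gives a 10-fold lower number from compound 3 to compound 4 (1.00 log units; beyond the scatter), whereas the only earlier step, no change at the digits printed from compound 1 to compound 2 (within the scatter), concerned an amide-type nitrogen. The two groups match in heavy atoms, hydrogen-bond donors, hydrogen-bond acceptors and net charge, so these counts do not separate them; what differs is nitrile against methoxy and the number in each group's name, and this single step changes both together. Nothing available bears on why the dose changes at this position.

From the compounds shown here alone, it remains open whether the shift follows the methoxy group, the loss of the nitrile or the place of the group on the ring, a question that 3-methoxyphenyl and 4-cyanophenyl would separate, and whether a 4-aminophenyl group would fall in line with either. Going by these compounds, it also remains open whether the same exchange carries the same size of step with the amide side of compound 1 or compound 2.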